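Silyl group size and cytotoxicity in a diterpenoid lactone series

The compounds below may be only part of what the source reports. "The series", "measured", "known", "first", "only" and "open" are said of these compounds alone.

Of the compounds shown here, three of a shared core have been measured in a functional assay on MCF7 cells (Homo sapiens) for cytotoxicity, read by sulforhodamine B assay; on this read-out higher numbers stand for an effect only at larger amounts of compound and lower numbers for an effect already at smaller amounts. Compound 1 `C=C1CC[C@@H]2[C@](C)(CO[Si](C(C)C)(C(C)C)C(C)C)[C@H](OC(C)=O)CC[C@@]2(C)[C@@H]1C/C=C1/C(=O)OC[C@H]1OC(C)=O` gives 14 uM. Compound 2 `C=C1CC[C@@H]2[C@](C)(CO[Si](C)(C)C(C)(C)C)[C@H](OC(C)=O)CC[C@@]2(C)[C@@H]1C/C=C1/C(=O)OC[C@H]1OC(C)=O` gives 2.84 uM, and compound 3 `C=C1CC[C@@H]2[C@](C)(CO[Si](C)(C)C(C)(C)C)[C@H](O)CC[C@@]2(C)[C@@H]1C/C=C1/C(=O)OC[C@H]1O` gives 47 uM, the highest of the three. Compound 2 and compound 1 differ in one place, (a group of 10 heavy atoms (9 carbon, 1 silicon; no ring) in place of a group of 7 heavy atoms (6 carbon, 1 silicon; no ring), on an oxygen on a saturated carbon), and that change gave a 4.9-fold higher number from compound 2 to compound 1 (0.69 log units; beyond the scatter). Compound 3 differs from compound 2 in more than one place, and the difference between the two cores is not broken down here.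

Compound 4 `C=C1CC[C@@H]2[C@](C)(CO[Si](C(C)C)(C(C)C)C(C)C)[C@H](O)CC[C@@]2(C)[C@@H]1C/C=C1/C(=O)OC[C@H]1O` has not yet been measured. It carries the same change relative to compound 3, namely (a group of 10 heavy atoms (9 carbon, 1 silicon; no ring) in place of a group of 7 heavy atoms (6 carbon, 1 silicon; no ring), on an oxygen on a saturated carbon), at a place described in the same words as for compound 2 and compound 1. Because compound 2 to compound 1 gave a 4.9-fold higher number from compound 2 to compound 1 (0.69 log units; beyond the scatter), a step of similar direction and roughly similar size is expected from compound 3 to compound 4, namely a 3.4-fold higher number from compound 3 to compound 4 (0.53 log units; beyond the scatter), with some uncertainty since the core differs and the change has been seen only once. Compound 4 is therefore estimated at 160 uM, expected to lie between 50 uM and 500 uM.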

Compound 4, concentration for half-maximal effect: 2.88 uM
Compound 4: the middle estimate sits 56-fold (1.74 log units) above what was measured; the measured number lies below the stated range.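

In this assay, putting the group of 10 heavy atoms in place of the group of 7 heavy atoms, on an oxygen on a saturated carbon, gave a 16-fold lower number from compound 3 to compound 4 (1.21 log units; beyond the scatter), so on the core of compound 3 the change goes with an effect at smaller amounts, the opposite direction to the earlier step. The same change therefore did not carry over from one core to the other, in either direction or size: the same change on two cores in this assay, a 4.9-fold higher number (0.69 log units; beyond the scatter) from compound 2 to compound 1 and a 16-fold lower number (1.21 log units; beyond the scatter) from compound 3 to compound 4, 80-fold (1.91 log units) apart, beyond the scatter of two such steps. Within the data shown here, this shows that the result of the change depends on the core it sits on, but with only one pair per core it does not show which feature of the core matters or why the direction reverses.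

On these data alone, it remains open whether the reversal would hold for other groups on that oxygen, such as a methyl ether, a benzyl group or a free hydroxyl. As far as these compounds go, it is also open whether a core with only one of the two acetate esters of compound 2 would follow compound 2 or compound 3.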